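Aryl variation on the bis-benzylidene core: cytotoxicity notes

This account rests on a few compounds, and the source may have more. Where it says the series, first, only, none or still open, it means among the compounds named here.

The series shares one core, shown in compound 1 `COc1ccccc1/C=C1\COC/C(=C\c2ccccc2F)C1=O`, and varies one of the two aryl groups while the 2-fluorophenyl side is kept. Measured in a functional assay on A549 cells (Homo sapiens) for cytotoxicity, read by MTT assay, with a stated time of 72 h (a lower number here means a stronger inhibitor, a higher number a weaker inhibitor), compound 1 gives 5900 nM, compound 2 `O=C1/C(=C/c2ccccc2F)COC/C1=C\c1ccc(Cl)cc1Cl` gives 7900 nM, and compound 3 `COc1ccc(/C=C2\COC/C(=C\c3ccccc3F)C2=O)cc1O` gives 13800 nM. Compound 2 stands second highest of the three numbers; its nearest neighbour is compound 1 and its furthest is compound 3, and both gaps lie within the scatter, so no order among the three can be claimed.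

Compound 4 `O=C1/C(=C/c2cccc(O)c2)COC/C1=C\c1ccccc1F` is not yet measured. It differs from compound 2 by 3-hydroxyphenyl in place of 2,4-dichlorophenyl on a double-bonded chain carbon bound to a double-bonded ring carbon

Within the data shown here, the one step so far that changes this aryl group, a 1.3-fold higher number from compound 1 to compound 2 (0.13 log units; within the scatter), stayed within the scatter. Compound 3, which also carries a hydroxyl on this aryl group, sits at the weaker end of the three numbers, though again within the scatter of compound 2. On that basis the expected step of a 1.1-fold higher number from compound 2 to compound 4 (0.06 log units; within the scatter) in this assay is small, with no direction beyond the scatter. Compound 4 is therefore estimated at 9000 nM, with a range of 4000 nM to 25000 nM.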

Compound 4, half-maximal inhibitory concentration: 7400 nM
The estimate for compound 4 lay 1.2-fold (0.09 log units) above the measured number; low and high end bracket the measured number.
By their numbers in this assay, from the lowest: compounds 1, 4, 2 and 3 (each within the scatter of the next, the first and the last beyond it).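

In this assay the place on a double-bonded chain carbon bound to a double-bonded ring carbon accepts 3-hydroxyphenyl, with 1 hydrogen-bond donor and 1 hydrogen-bond acceptor, in place of 2,4-dichlorophenyl, with 0 of each: a 1.1-fold lower number from compound 2 to compound 4 (0.03 log units; within the scatter) is a step that shows no effect of this exchange beyond the scatter. The comparison with 2-methoxyphenyl reads the same, as a 1.3-fold higher number from compound 1 to compound 4 (0.10 log units; within the scatter) also stays within the scatter, and so does the exchange of methoxy for hydrogen on an aromatic carbon, seen in a 1.9-fold lower number from compound 3 to compound 4 (0.27 log units; within the scatter) as the third step. All three steps therefore extend the flat picture at this place to a hydroxyl-bearing aryl group without a methoxy, and nothing at hand explains this flatness.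

The compounds shown leave open whether an amine, a carboxylic acid or a longer chain in place of these aryl groups would move the number beyond the scatter. They also leave open how far the number depends on the 2-fluorophenyl group, which all four compounds carry unchanged.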